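The source may report more compounds than this note shows. Statements on the series, on what has been measured and on what is new or still open speak of the compounds shown alone.

Measured so far:
compound 1 `ClCc1ccc(Cn2cnc3nc(Cl)nc(Cl)c32)cc1`, 64600 nM
compound 2 `ClCc1ccccc1Cn1cnc2ncnc(Cl)c21`, 10000 nM
compound 3 `ClCc1ccccc1Cn1cnc2nc(Cl)nc(Cl)c21`, 4670 nM

All three were tested in a functional assay on SW-620 cells (Homo sapiens) for cytotoxicity, read by sulforhodamine B assay, with a stated time of 48 h; on this read-out higher numbers stand for lower toxicity in this test and lower numbers for higher toxicity in this test. Compound 1 gives the highest number of the three, so it is the least toxic here. Compound 3 carries two chloro groups on its core; compound 2 keeps only one, the change being (hydrogen in place of chloro on an aromatic carbon). That step, a 2.1-fold higher number from compound 3 to compound 2 (0.33 log units; beyond the scatter), made the number larger. The difference between the core of compound 1 and the core of compound 3 is not broken down here, since the two differ in more than one place.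

Compound 4 `ClCc1ccc(Cn2cnc3ncnc(Cl)c32)cc1` has not yet been measured. It relates to compound 1 as compound 2 does to compound 3: the change is hydrogen in place of chloro on an aromatic carbon, and the surroundings of the place are described the same way in both cases, so this is the same change. Because compound 1 already stands at 64600 nM and the step of a 2.1-fold higher number from compound 3 to compound 2 (0.33 log units; beyond the scatter) was modest, a step of similar size is expected, a 2.0-fold higher number from compound 1 to compound 4 (0.30 log units; within the scatter). The estimated value for compound 4 in this assay is 130000 nM, expected to fall between 50000 nM and 320000 nM.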

Compound 4, concentration lethal to 50% of the cells: 32400 nM
Compound 4: middle estimate off by 4.0-fold (0.60 log units), on the high side, outside the stated range (below it).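

In this assay, swapping chloro for hydrogen on the same aromatic carbon did not give the same result on the two cores: the same change on two cores in this assay, a 2.1-fold higher number (0.33 log units; beyond the scatter) from compound 3 to compound 2 and a 2.0-fold lower number (0.30 log units; within the scatter) from compound 1 to compound 4, 4.3-fold (0.63 log units) apart, beyond the scatter of two such steps. The new step, a 2.0-fold lower number from compound 1 to compound 4 (0.30 log units; within the scatter), lies within the usual scatter when taken alone, so it does not establish a real change on the core of compound 1, but it also does not repeat the earlier step. The result shows that a step measured on one core cannot simply be carried to the other here, but it does not show why, and two pairs set no rule for the series. As far as these compounds go, it remains open how an amine or a methoxy group on that carbon would compare with chloro and hydrogen on each core.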